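Trimming the Sulfonamide: From Compound 1 to Compound 4

A few compounds are considered here, and "the series" means these few. Any claim that something is new, unique, unknown or untested is made for them only; others in the source may bear on it.

Compound 1 `CCOC1Oc2ccccc2C(=O)/C1=C/Nc1ccc(S(=O)(=O)Nc2cc(C)on2)cc1` was tested in a functional assay on A549 cells (Homo sapiens) for cytotoxicity, read by sulforhodamine B assay, with a stated time of 72 h (on this read-out higher numbers stand for weaker inhibition and lower numbers for stronger inhibition), and gave 57200 nM. Its closest companion on this read-out is compound 2 `Cc1cc(C)nc(NS(=O)(=O)c2ccc(N3C(=O)/C(=C/c4coc5ccccc5c4=O)N=C3c3ccccc3)cc2)n1`, which in this assay gives 63200 nM, a gap that lies within the usual scatter, so the two cannot be ranked against each other. Compound 3 `Cc1cc(NS(=O)(=O)c2ccc(N3C(=O)/C(=C/c4coc5ccccc5c4=O)N=C3c3ccc(Cl)cc3)cc2)no1` reaches only a limit of this assay, > 100000 nM. That limit, (the limit of > 100000 nM in this assay, at which 1 of the 3 values shown sits), shows how easily compounds of this kind fall out of the measurable range.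

Compound 4 `CCOC1Oc2ccccc2C(=O)/C1=C/Nc1ccc(S(N)(=O)=O)cc1` has not yet been measured. It differs from compound 1 in one place: hydrogen in place of 5-methyl-1,2-oxazol-3-yl on a sulfonamide nitrogen. Within the data shown here, no step between two measured compounds resembles this change, so there is no direct guide to its size. Given the weak inhibition throughout the set, the step is expected to be small and, if anything, towards weaker inhibition: a 1.4-fold higher number from compound 1 to compound 4 (0.15 log units; within the scatter). Compound 4 is therefore expected to give about 80000 nM in this assay, with a likely range from 30000 nM to 200000 nM, and a fair chance that only a limit is reported.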

Compound 4, half-maximal inhibitory concentration: 33400 nM
Beside the measured number, compound 4's estimate is 2.4-fold (0.38 log units) above it; measured number inside the range.
By their numbers in this assay, from the lowest: compounds 4, 1 and 2 (each within the scatter of the next). At a limit, above all of these: compound 3.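

In this assay, hydrogen in place of 5-methyl-1,2-oxazol-3-yl on the sulfonamide nitrogen gives a 1.7-fold lower number from compound 1 to compound 4 (0.23 log units; within the scatter). Among these compounds, this is the first measured change at this place, and it shows that an entire aromatic ring of 6 heavy atoms can be removed from the sulfonamide nitrogen with no change that can be told from scatter, so the ring is not needed for the modest cytotoxicity seen with compound 1. The data shown contain no measurement that accounts for this result.

On these data alone, what remains open is whether any other group on this nitrogen, such as a methyl group, an acetyl group or a phenyl ring, would move the number beyond the scatter. With only the two ends of the range shown here, hydrogen and the 5-methyl-1,2-oxazol-3-yl ring, no trend at this place can be drawn.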